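From Phenyl to 4-Methoxyphenyl: One Small Change Under Test

The source may hold more compounds than are shown below. What is called first, only, known or untested is meant among the compounds shown, and "the series" means these compounds.

Going by the values given here, in an ADME assay on NL20 cells (Homo sapiens) for antiproliferative activity, read by MTT assay, with a stated time of 24 h (a lower number here means a stronger inhibitor, a higher number a weaker inhibitor), compound 2 (`O=C(/C=C/c1ccc(O)c(O)c1)NNC(=O)c1ccccc1`) gives 8850 nM as the only true number so far. Compound 1 (`COc1ccc(C(=O)NNC(=O)/C=C/c2ccc(O)c(OC)c2)cc1`) reads > 10000 nM and that entry is a limit of the assay, not a number. Compound 2 therefore stands alone as a measured point, with no second number to rank it against. The next compound, compound 3 (`COc1ccc(C(=O)NNC(=O)/C=C/c2ccc(O)c(O)c2)cc1`), is compound 2 with methoxy in place of hydrogen on an aromatic carbon, para to a large group, so that phenyl becomes 4-methoxyphenyl (methoxy in place of hydrogen on an aromatic carbon). Among the compounds with values here, no two measured compounds differ in just one place, so no measured step shows what such a swap does in this assay here. The working expectation is therefore no step beyond the usual scatter of repeat measurements. The expected change is a 1.1-fold higher number from compound 2 to compound 3 (0.03 log units; within the scatter) and so stays within that scatter. For compound 3 the estimated value is 9500 nM with an expected range from 4500 nM to 20000 nM and a real chance of only a limit of the assay.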

Compound 3, half-maximal inhibitory concentration: 9390 nM
Compound 3: the middle estimate sits 1.0-fold (0.01 log units) above what was measured, within the range that was stated.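

In this assay, methoxy in place of hydrogen on an aromatic carbon, para to a large group, gives a 1.1-fold higher number from compound 2 to compound 3 (0.03 log units; within the scatter). Going by these compounds alone, this is the first measured step between two compounds that differ in one place, and it shows that turning phenyl into 4-methoxyphenyl leaves the reading within the usual scatter. Compound 1 reads > 10000 nM, which is a limit of the assay and not a number, so hydrogen in place of methyl on an oxygen on an aromatic ring can be read only as a floor, an at least 1.0-fold lower number from compound 1 to compound 3 (0.02 log units; that floor lies within the scatter), and the true size of that step stays unknown: the limit of > 10000 nM in this assay, at which 1 of the 3 values shown sits.

One swap at one position cannot tell whether a different group in the same place, such as an amine, a carboxylic acid or a longer chain like butoxy, would shift the number beyond the scatter. It also leaves open whether methoxy would behave the same way on a different core.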